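Chloro to fluoro swap on the chlorinated sulfonamide compound 2

The source may hold more compounds than are shown below. What is called first, only, known or untested is meant among the compounds shown, and "the series" means these compounds.

Of the compounds shown here, two have been measured so far in a functional assay on MC-38 cells (Mus musculus) for antiproliferative activity, read by colorimetric assay and MTT assay; on this read-out lower numbers stand for stronger inhibition and higher numbers for weaker inhibition. Compound 1 (`Nc1ccc(S(=O)(=O)Nc2cccc3c(Cl)c[nH]c23)cc1`) gives 0.23 ug/mL, and compound 2 (`Nc1ccc(S(=O)(=O)Nc2ccc(Cl)c3c(Cl)c[nH]c23)cc1`) gives 0.1 ug/mL, the lower of the two numbers. The next compound to read is compound 3 (`Nc1ccc(S(=O)(=O)Nc2ccc(F)c3c(Cl)c[nH]c23)cc1`). The change is fluoro in place of chloro on an aromatic carbon, in words fluoro in place of chloro on an aromatic carbon.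

Within the data shown here, only one measured step bears on this. The step of a 2.3-fold lower number from compound 1 to compound 2 (0.36 log units; beyond the scatter) is modest but beyond the scatter, and it comes from chloro in place of hydrogen on the same carbon. Among the measured compounds shown here, no fluoro compound has been measured, so this step only brackets the expectation. Its two ends are hydrogen and chloro, and fluoro is expected to lie within that span or close to it. A small move toward a higher number is therefore expected in this assay, possibly no larger than the scatter. The expected step is a 1.5-fold higher number from compound 2 to compound 3 (0.18 log units; within the scatter). For compound 3 the estimated value is 0.15 ug/mL, with an expected range of 0.07 ug/mL to 0.35 ug/mL.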

Compound 3, half-maximal inhibitory concentration: 0.11 ug/mL
Estimate against measurement, compound 3: 1.4-fold (0.13 log units) above; measured number inside the range.
By their numbers in this assay, from the lowest: compounds 2 and 3 (each within the scatter of the next); then compound 1.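

In this assay, fluoro in place of chloro on this carbon, para to a large group, gives a 1.1-fold higher number from compound 2 to compound 3 (0.04 log units; within the scatter) and leaves the read-out unchanged within the scatter, so chloro and fluoro cannot be told apart here. Fluoro also gives a 2.1-fold lower number from compound 1 to compound 3 (0.32 log units; beyond the scatter) and so stands with chloro, which gives a 2.3-fold lower number from compound 1 to compound 2 (0.36 log units; beyond the scatter); each halogen step from hydrogen is modest but beyond the scatter, so the drop seen with compound 2 is not confined to chloro among the compounds shown. Nothing at hand explains why the two halogens read alike.

Going by these compounds, whether a bromo, methyl or methoxy group on this carbon would read with the two halogens or with hydrogen remains open, and only these three groups can be compared here. On these data alone, the contribution of the amino group and of the chloro group shared by all three compounds also remains open, as does whether the match between compound 2 and compound 3 would hold outside this assay.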